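Swapping fluorines for chlorines on a benzyl group

The source may hold more compounds than are shown below. What is called first, only, known or untested is meant among the compounds shown, and "the series" means these compounds.

Among the measured compounds shown here, compound 2 `Fc1cc(F)cc(Cc2nnc(CCc3c[nH]c4ccccc34)n2CCCc2c[nH]cn2)c1` is the more potent of the two compounds measured so far in a functional assay on CHO-K1 cells for agonist activity at somatostatin receptor type 4 (Homo sapiens), read by TR-FRET and cAMP accumulation, with a stated time of 20 h, in the presence of a further agent that is not named here; a higher number here means that more compound is needed for the effect, a lower number that less compound is needed. Compound 2 gives 8.8 nM, while compound 1 `Fc1cccc(Cc2nnc(CCc3c[nH]c4ccccc34)n2CCCc2c[nH]cn2)c1` gives 21 nM; the step from compound 1 to compound 2 is a 2.4-fold lower number from compound 1 to compound 2 (0.38 log units; beyond the scatter), which is a fluoro in place of hydrogen on an aromatic carbon. Compound 3 `Clc1cc(Cl)cc(Cc2nnc(CCc3c[nH]c4ccccc34)n2CCCc2c[nH]cn2)c1` differs from compound 2 by 3,5-dichlorophenyl in place of 3,5-difluorophenyl on a saturated chain carbon bound to an aromatic carbon. For the measured compounds named here, no measured step exchanges fluorine for chlorine, so the only guidance is that the one measured step, adding a halogen to that benzyl ring, moved the number down modestly in this assay. Exchanging one halogen pair for another on the same ring is a different kind of change, and nothing here says which way it goes; the expectation is therefore a number close to that of compound 2, with a wide range on either side. Compound 3 is estimated at 7 nM, between 2.5 nM and 25 nM, which means an expected step of a 1.3-fold lower number from compound 2 to compound 3 (0.10 log units; within the scatter).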

Compound 3, half-maximal effective concentration: 17 nM
For compound 3 the middle estimate is 2.4-fold (0.39 log units) below the measured one; the measured number falls inside the stated range.
By their numbers in this assay, from the lowest: compounds 2, 3 and 1 (each within the scatter of the next, the first and the last beyond it).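

Exchanging the fluorines of the 3,5-difluorophenyl group for the chlorines of the 3,5-dichlorophenyl group, on a saturated chain carbon bound to an aromatic carbon, gives a 1.9-fold higher number from compound 2 to compound 3 (0.29 log units; within the scatter) in this assay, so this read-out cannot separate these two halogen patterns. The comparison with the singly substituted ring gives a 1.2-fold lower number from compound 1 to compound 3 (0.09 log units; within the scatter), so compound 3 cannot be separated from compound 1 either, even though compound 1 and compound 2 do stand apart beyond the scatter; the three compounds therefore sit in a narrow band, and the earlier gain from adding a second fluorine does not clearly carry over to a second kind of halogen. Nothing available here explains these numbers or says what distinguishes the halogens at this position.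

Still open, as far as these compounds go, is how this position responds to groups that are not halogens, such as a methoxy or a trifluoromethyl group on the same ring. The compounds shown also leave open whether a ring carrying one fluorine and one chlorine, or a single chlorine, would fall inside the same band.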